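The source may hold more compounds than are shown below. What is called first, only, known or untested is meant among the compounds shown, and "the series" means these compounds.

Working notes on the series. In a functional assay on HepG2 cells (Homo sapiens) for cytotoxicity, read by MTT assay, with a stated time of 48 h (on this read-out higher numbers stand for weaker inhibition and lower numbers for stronger inhibition), compound 1 (`CCN(CC)CC(=O)N1N=C(C)CC1c1ccccc1O`) gives 51600 nM, compound 2 (`CC1=NN(C(=O)CN2CCC(Cl)CC2)C(c2ccccc2O)C1`) gives 42100 nM, and compound 3 (`CCN(CC)CC(=O)N1N=C(C)CC1c1ccccc1OC(C)=O`) gives 33200 nM. Compound 3 thus stands within the scatter of both other compounds. Compound 4 (`CC(=O)Oc1ccccc1C1CC(C)=NN1C(=O)CN1CCCCC1`) is not yet measured. The change from compound 3 to compound 4 is piperidin-1-yl in place of diethylamino on a saturated chain carbon bound to a carbonyl carbon, in words piperidin-1-yl in place of diethylamino on a saturated chain carbon bound to a carbonyl carbon.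

The closest measured precedent is a 1.2-fold lower number from compound 1 to compound 2 (0.09 log units; within the scatter), with 4-chloropiperidin-1-yl in place of diethylamino at that same place. The other measured step, a 1.6-fold lower number from compound 1 to compound 3 (0.19 log units; within the scatter), has acetyl in place of hydrogen on an oxygen on an aromatic ring, and bears only on the background of the change. Going by the values given here, both steps lie within the scatter, and no measured pair has piperidin-1-yl itself. No step beyond the scatter is therefore expected in this assay.

The expected step is a 1.1-fold lower number from compound 3 to compound 4 (0.04 log units; within the scatter). Compound 4 is estimated at 30000 nM, with an expected range of 15000 nM to 60000 nM.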

Compound 4, half-maximal inhibitory concentration: 19000 nM
Compound 4: middle estimate off by 1.6-fold (0.20 log units), on the high side; the measured number falls inside the stated range.
By their numbers in this assay, from the lowest: compounds 4, 3, 2 and 1 (each within the scatter of the next, the first and the last beyond it).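

In this assay, piperidin-1-yl now has a step of its own on a saturated chain carbon bound to a carbonyl carbon: a 1.7-fold lower number from compound 3 to compound 4 (0.24 log units; within the scatter). With a 1.2-fold lower number from compound 1 to compound 2 (0.09 log units; within the scatter), there are two exchanges of diethylamino for a six-membered ring at this place, one with hydrogen and one with acetyl on the oxygen on the aromatic ring, and both stay within the scatter. No available data account for the step in compound 4.

As far as these compounds go, it remains open whether morpholin-4-yl, piperazin-1-yl or a carboxylic acid at this place would give a step beyond the scatter. Also open, from the compounds shown here alone, is the size of the piperidin-1-yl exchange with hydrogen in place of acetyl on the oxygen on the aromatic ring.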